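This account rests on a few compounds, and the source may have more. Where it says the series, first, only, none or still open, it means among the compounds named here.

Compound 1 `CCC(CC)(c1ccc(OC[C@@H](O)CO)c(C)c1)c1ccc(OC[C@H](O)C(C)(C)OCCCCCCCCO)c(C)c1` is measured in an assay on HEK293 cells for agonist activity at vitamin D3 receptor (Homo sapiens), read by a beta-galactosidase reporter (on this read-out higher numbers stand for an effect only at larger amounts of compound and lower numbers for an effect already at smaller amounts), where compound 1 gives 1200 nM. Compound 2 `CCCCCCCCCCOC(C)(C)[C@@H](O)COc1ccc(C(CC)(CC)c2ccc(OC[C@@H](O)CO)c(C)c2)cc1C`, tested in this assay, gives "not active" (no number reported), and no number was reported for compound 2, so compound 2 stands below any stated value. Compound 3 `CCCCCCCCOC(C)(C)[C@@H](O)COc1ccc(C(CC)(CC)c2ccc(OC[C@@H](O)CO)c(C)c2)cc1C` differs from compound 2 only by hydrogen in place of ethyl on a saturated chain carbon, eight bonds along the chain from an oxygen on a saturated carbon. For the measured compounds named here, no step between measured compounds is known, and a hydrogen in place of ethyl on a saturated chain carbon is expected to give at most a modest change in this assay in either direction. Compound 3 is therefore estimated at 6000 nM, with a range from 1500 nM to 30000 nM.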

Compound 3, half-maximal effective concentration: "not active" (no number reported)
Compound 3: no number reported; no gap can be computed for the estimate.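

Compound 3, like compound 2, is reported as not active with no number, so no step can be read between them. The compounds shown leave open what hydrogen in place of ethyl does to activity. No measured evidence bears on this result.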